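This account rests on a few compounds, and the source may have more. Where it says the series, first, only, none or still open, it means among the compounds named here.

Three compounds have been examined in a physicochemical assay for solubility, read by HPLC, using the shake flask method, measured as kinetic solubility, with a stated time of 20 h, at pH 6.5, tested at 200 uM; a higher number here means a more soluble compound, a lower number a less soluble compound. Compound 1 `NS(=O)(=O)c1cccc(-c2ccc3nccc(-c4ccncc4F)c3n2)c1` gives only a limit, < 5000 nM. Compound 2 `CS(=O)(=O)c1cccc(-c2ccc3nccc(-c4ccncc4)c3n2)c1` also gives only a limit, < 5000 nM, so it sits at the limit of < 5000 nM in this assay, at which 2 of the 3 values shown sit. Compound 3 `CS(=O)(=O)c1cccc(-c2ccc3nccc(N4CCNCC4)c3n2)c1` gives 165000 nM, and the step of an at least 33-fold higher number from compound 2 to compound 3 (1.51 log units; beyond the scatter) is large. Compound 4 `O=S(=O)(c1cccc(-c2ccc3nccc(-c4ccncc4)c3n2)c1)N1CC[C@H](O)C1` differs from compound 2 at another place: 3-hydroxypyrrolidin-1-yl in place of methyl on a sulfonyl sulfur. For the measured compounds named here, no measured step touches the sulfonyl sulfur, so the only known step, from compound 2 to compound 3, changes a different part of the core and gives no direct guide. A moderate rise in this assay is nonetheless expected, so that compound 4 is estimated at 15000 nM, between 3000 nM and 60000 nM, a step of an at least 3.0-fold higher number from compound 2 to compound 4 (0.47 log units; beyond the scatter).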

Compound 4, solubility: 20000 nM
Estimate against measurement, compound 4: 1.3-fold (0.12 log units) below; the measured number falls inside the stated range.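

In this assay the sulfonyl sulfur proves to be a second place that moves the number, with an at least 4.0-fold higher number from compound 2 to compound 4 (0.60 log units; beyond the scatter) for 3-hydroxypyrrolidin-1-yl in place of methyl. Compound 4 keeps the pyridin-4-yl group that compound 3 lacks, so that group need not be replaced for a rise. Going by these compounds, the full size of this step stays unknown, since compound 2 gives only a limit: the limit of < 5000 nM in this assay, at which 2 of the 4 values shown sit. On these data alone, whether the ring or its hydroxyl carries the rise stays open. An unsubstituted pyrrolidine or a small open-chain amine such as dimethylamine on the sulfonyl sulfur would separate the two.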